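The source may report more compounds than this note shows. Statements on the series, on what has been measured and on what is new or still open speak of the compounds shown alone.

Measured so far in a physicochemical assay for solubility, read by HPLC, using the shake flask method, measured as kinetic solubility, with a stated time of 20 h, at pH 6.5, tested at 200 uM; on this read-out lower numbers stand for lower solubility and higher numbers for higher solubility:
compound 1 `O=S(=O)(NCC1COC1)c1cccc(-c2ccc3nccc(-c4ccncc4)c3n2)c1`: 20000 nM
compound 2 `NS(=O)(=O)c1cccc(-c2ccc3nccc(-c4ccncc4)c3n2)c1`: < 5000 nM (a limit)
compound 3 `CS(=O)(=O)c1cccc(-c2ccc3nccc(-c4ccncc4)c3n2)c1`: < 5000 nM (a limit)

Compound 2 gives no number in this assay, only the limit < 5000 nM. Compound 3 is also held at a limit, < 5000 nM. Compound 1 alone gives a number, 20000 nM. The evidence therefore rests largely on (the limit of < 5000 nM in this assay, at which 2 of the 3 values shown sit).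

Compound 4 `NS(=O)(=O)c1cccc(-c2ccc3nccc(-c4cn[nH]c4)c3n2)c1` keeps the sulfonamide of compound 2 and differs on an aromatic carbon of the shared core, where 1H-pyrazol-4-yl stands in place of pyridin-4-yl: 1H-pyrazol-4-yl in place of pyridin-4-yl on an aromatic carbon.

Among the compounds with values here, all the measured steps lie on the sulfonyl side: there is an at least 4.0-fold lower number from compound 1 to compound 2 (0.60 log units; beyond the scatter), there is an at least 4.0-fold lower number from compound 1 to compound 3 (0.60 log units; beyond the scatter), and there is a step that the two limits leave unreadable from compound 2 to compound 3. The first two are beyond the scatter, and the third cannot be sized. None of them changes the pyridin-4-yl, so none gives a size for this replacement. With no measured guide, no step beyond the scatter is expected in this assay, in either direction, and the assay may again report only a limit. The expected step is a step that the limit leaves unreadable from compound 2 to compound 4. For compound 4 the estimated value is 4000 nM, with an expected range from 1200 nM to 12000 nM.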

Compound 4, solubility: < 5000 nM
Compound 4: a limit, no number; the forecaster's own chance of this, stated with the estimate: 65%; the middle value lies beyond the limit too.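

Compound 4 gives only a limit, not a number, in this assay: < 5000 nM. Compound 2 is held at a limit as well, so no step can be read between compound 2 and compound 4. The compounds shown leave open whether 1H-pyrazol-4-yl in place of pyridin-4-yl changes the read-out in this assay at all, and in which direction.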